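This account rests on a few compounds, and the source may have more. Where it says the series, first, only, none or still open, it means among the compounds named here.

Measured in an ADME assay on Vero cells (Chlorocebus sabaeus) for cytotoxicity, read by resazurin assay, with a stated time of 72 h; a higher number here means that more compound is needed for the effect, a lower number that less compound is needed:
Compound 1 `FC(F)(F)SCCOc1ccc(Oc2ccccc2)cc1`: > 20 uM
Compound 2 `FC(F)(F)[Se]CCOc1ccc(Oc2ccccc2)cc1`: > 20 uM
Compound 3 `N#CCCOc1ccc(Oc2ccccc2)cc1`: > 20 uM

Each of these entries is a limit of the assay and not a number, and together they make up the whole record so far: the limit of > 20 uM in this assay, at which 3 of the 3 values shown sit. In this assay compound 3 stands at > 20 uM, which is a limit, so it cannot be ranked against the other two.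

The next compound is compound 4 `N#CCCCOc1ccc(Oc2ccccc2)cc1`, and the change is cyanomethyl in place of cyano on a saturated chain carbon, two bonds along the chain from an oxygen on an aromatic ring. Put another way, 2-cyanoethoxy gives way to 3-cyanopropoxy. The triple bond and the single hydrogen-bond acceptor remain, and no net charge enters.

For the measured compounds named here, three measured steps concern this same place on the chain: a step that the two limits leave unreadable from compound 1 to compound 2, a step that the two limits leave unreadable from compound 1 to compound 3 and a step that the two limits leave unreadable from compound 2 to compound 3. None of them has a readable size, and all three end at the same limit. A change beyond the usual scatter in this assay is therefore not expected, and no direction can be given. The expected step is a step that the limit leaves unreadable from compound 3 to compound 4. Another report of only a limit is the likeliest outcome. The estimate for compound 4 is 30 uM, with an expected range from 15 uM to 60 uM.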

Compound 4, concentration for half-maximal effect: > 20 uM
Compound 4 gave a limit, no number; the forecaster's own chance of this, stated with the estimate: 85%; the middle value does not contradict the limit.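

In this assay, for the compounds shown here, no step to compound 4 from compound 1, compound 2 or compound 3 can be read, because all four compounds stand at the same limit and not at a number: the limit of > 20 uM in this assay, at which 4 of the 4 values shown sit. The compounds shown leave open whether these four differ at all, and at what concentration any of them would reach the half-maximal effect.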